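Swapping a methyl for a chloro on the amide-side ring

The source may hold more compounds than are shown below. What is called first, only, known or untested is meant among the compounds shown, and "the series" means these compounds.

Of the compounds shown here, two sharing one core have been measured so far. Compound 1 `O=C(Nc1cc(-c2ccccc2)nn1-c1ccccc1)c1ccccc1` carries an unsubstituted ring on the amide side, and in an assay on CHO cells with metabotropic glutamate receptor 5 (Homo sapiens) as the target (a higher number here means that more compound is needed for the effect, a lower number that less compound is needed), compound 1 gives 40 nM. Compound 2 `Cc1cccc(C(=O)Nc2cc(-c3ccccc3)nn2-c2ccccc2)c1` carries a methyl on that ring, and in this assay compound 2 gives 90 nM. For the measured compounds named here, compound 2 therefore stands with the higher of the two numbers: the one step measured, a 2.3-fold higher number from compound 1 to compound 2 (0.35 log units; beyond the scatter), shows that putting a methyl onto that aromatic carbon raised the number by a modest amount, beyond the scatter.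

Compound 3 `O=C(Nc1cc(-c2ccccc2)nn1-c1ccccc1)c1cccc(Cl)c1` is the next step. It differs from compound 2 in one place: chloro in place of methyl on an aromatic carbon. Going by the values given here, no measured pair shows a chloro at this position, so the only guidance is the methyl step, which tells how the bare ring and the methyl-bearing ring compare, not how chloro and methyl compare. A single atom traded for a single atom of similar size gives no reason to expect a large movement. The step from compound 2 is therefore expected to be a 1.1-fold lower number from compound 2 to compound 3 (0.05 log units; within the scatter), within the scatter. Compound 3 is estimated at 80 nM, with a range from 30 nM to 220 nM.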

Compound 3, half-maximal effective concentration: 40 nM
Compound 3: middle estimate off by 2.0-fold (0.30 log units), on the high side; measured number inside the range.
By their numbers in this assay, from the lowest: compounds 1 and 3 (each within the scatter of the next); then compound 2.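

The two single-atom groups do not behave alike at this place on the amide-side ring: in this assay, the trade of methyl for chloro gives a 2.3-fold lower number from compound 2 to compound 3 (0.35 log units; beyond the scatter), so what the methyl step showed does not carry over to every group of one heavy atom. Set against the bare ring, chloro shows no change at the digits printed from compound 1 to compound 3 (within the scatter), which means that hydrogen and chloro cannot be told apart here, and that among the three compounds only the methyl of compound 2 stands apart, with the higher number. Nothing at hand explains why methyl and chloro part ways at this position.

On these data alone, whether larger or different groups at the same place, such as a methoxy, an amine or a carboxylic acid, would stay level with the bare ring or move away from it remains open. As far as these compounds go, it also remains open whether a chloro on the other aromatic rings of the shared core would leave the number as undisturbed as it does on this ring.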